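The source may hold more compounds than are shown below. What is called first, only, known or untested is meant among the compounds shown, and "the series" means these compounds.

Working notes on the series. The shared core is set by compound 1 `Cc1nc2sc(-c3ccccc3)nc2c(=O)[nH]1`. Among the measured compounds shown here, in an assay on CHO cells for displacement of a labelled ligand from adenosine receptor A1 (Homo sapiens), read by scintillation counting, with a stated time of 120 min, tested at 1 uM (on this read-out lower numbers stand for less inhibition and higher numbers for more inhibition at the one concentration tested (going by the name of the read-out)), compound 1 gives 11%, the second highest of the three numbers so far, with compound 2 `Cc1ccc(-c2nc3c(=O)[nH]c(C)nc3s2)cc1` nearest at 17% and compound 3 `Cc1nc2sc(-c3ccc(C(=O)O)cc3)nc2c(=O)[nH]1` furthest at 1%. For the measured compounds named here, the step of a number 6 percentage points higher from compound 1 to compound 2 (within the scatter) and the step of a number 10 percentage points lower from compound 1 to compound 3 (within the scatter) both stay within the scatter; only the step of a number 16 percentage points lower from compound 2 to compound 3 (beyond the scatter) reaches beyond it, and that one is modest.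

Compound 4 `Cc1nc2sc(-c3cccc(C(F)(F)F)c3)nc2c(=O)[nH]1` is the next candidate. Its change from compound 1 is trifluoromethyl in place of hydrogen on an aromatic carbon. Going by the values given here, no measured step brings in this group, and none touches this place on the six-membered aromatic ring of carbon only; the steps that bear on it are the two other substitutions on that ring, a number 6 percentage points higher from compound 1 to compound 2 (within the scatter) and a number 10 percentage points lower from compound 1 to compound 3 (within the scatter), neither of which moves the number beyond the scatter. On that basis no step beyond the scatter is expected for compound 4 in this assay, in either direction, and the number is expected to sit close to that of compound 1. The estimate for compound 4 in this assay is 12%, with a range from 0% to 30%. This corresponds to an expected step of a number 1 percentage points higher from compound 1 to compound 4 (within the scatter).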

Compound 4, a percentage reported as inhibition, at one concentration (the size of the read-out at that concentration, not a potency): 1%
Compound 4: the middle estimate sits 11 percentage points above what was measured; the measured number falls inside the stated range.
By their numbers in this assay, from the lowest: compounds 3, 4, 1 and 2 (each within the scatter of the next, the first and the last beyond it).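

In this assay, trifluoromethyl in place of hydrogen on an aromatic carbon, meta to a large group, gives a number 10 percentage points lower from compound 1 to compound 4 (within the scatter), so this first substituent at this place on the six-membered aromatic ring of carbon only does not take the number beyond the scatter in either direction. Together with a number 6 percentage points higher from compound 1 to compound 2 (within the scatter) and a number 10 percentage points lower from compound 1 to compound 3 (within the scatter), it makes three substitutions on this ring read against compound 1, and all three stay within the scatter. No separate measurement bears on why trifluoromethyl at this place gives this result.

The compounds shown leave open whether an amine, a methoxy group or a longer chain at this same place would take the number beyond the scatter from that of compound 1. Also open, as far as these compounds go, is whether a longer chain in place of the methyl on the shared core, or a change at the amide hydrogen, would shift the number in this assay by more than the substitutions on the ring have so far.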